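This account rests on a few compounds, and the source may have more. Where it says the series, first, only, none or still open, it means among the compounds named here.

Three compounds on one shared core have so far been taken into a functional assay on G-361 cells (Homo sapiens) for antiproliferative activity, with a stated time of 72 h (a lower number here means a stronger inhibitor, a higher number a weaker inhibitor), and the record is thin. Compound 1 `OC[C@H]1O[C@@H](n2cnc3c(NCc4ccccc4Cl)ncnc32)[C@H](O)[C@@H]1O` has no result, only the entry "not determined" (no result reported). Compound 2 `Cc1cccc(CNc2ncnc3c2ncn3[C@@H]2O[C@H](CO)[C@@H](O)[C@H]2O)c1` gives > 166000 nM, which is a limit and not a number. Compound 3 `COc1cc(CNc2ncnc3c2ncn3[C@@H]2O[C@H](CO)[C@@H](O)[C@H]2O)cc(OC)c1` also stands without a figure, with the entry "not determined" (no result reported), so it offers no measured starting point.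

Compound 4 `OC[C@H]1O[C@@H](n2cnc3c(NCc4ccc(F)c(F)c4F)ncnc32)[C@H](O)[C@@H]1O` has yet to be measured in this assay. It differs from compound 3 in one place: 2,3,4-trifluorophenyl in place of 3,5-dimethoxyphenyl on a saturated chain carbon bound to a nitrogen on an aromatic ring. No measured step among these compounds shows what such an exchange does, and no step from compound 3 can be sized. Going by the values given here, the only reading to lean on is the limit of compound 2 at > 166000 nM. Against that limit, a moderate step towards stronger inhibition is expected, with compound 4 still expected to be a weak inhibitor, and the assay may again return only a limit. The half-maximal inhibitory concentration of compound 4 is estimated at 40000 nM, with an expected range from 5000 nM to 166000 nM.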

Compound 4, half-maximal inhibitory concentration: > 166000 nM
Compound 4 gave a limit, no number (the forecaster's own chance of this, stated with the estimate: 40%); middle value at least 4.1-fold (0.61 log units) from the limit.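

Going by these compounds alone, with compound 2 and compound 4 both resting on limits, the step between them cannot be read, and compound 3 offers no new step either. The compounds shown leave open whether any group in this place on the shared core gives a readable number in this assay.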